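This account rests on a few compounds, and the source may have more. Where it says the series, first, only, none or still open, it means among the compounds named here.

Compound 1 `COc1cc(/C(Cl)=C/C=C(\C#N)C(=O)c2c[nH]c3ccc(Br)cc23)cc(OC)c1OC` and compound 2 `COc1ccc(/C(Cl)=C/C=C(\C#N)C(=O)c2c[nH]c3ccc(Br)cc23)cc1OC` share one core and differ only by a hydrogen in place of a methoxy on an aromatic carbon. In a functional assay on MCF7 cells (Homo sapiens) for cytotoxicity, read by sulforhodamine B assay, with a stated time of 48 h (on this read-out lower numbers stand for stronger inhibition of growth and higher numbers for weaker inhibition of growth), compound 1 gives 30800 nM, and in the same assay compound 2 gives 31900 nM. Going by the values given here, the single measured step, a 1.0-fold higher number from compound 1 to compound 2 (0.02 log units; within the scatter), leaves the read-out where it was. Compound 1 therefore holds the lower of the two numbers, but compound 2 sits within the scatter of it, so no order between them can be claimed.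

Compound 3 `COc1cc(/C(Cl)=C/C=C(\C#N)C(=O)c2c(C)[nH]c3ccccc23)cc(OC)c1OC` has not yet been measured in this assay. It differs from compound 1 at the group on the carbonyl carbon: 2-methyl-1H-indol-3-yl in place of 5-bromo-1H-indol-3-yl on a carbonyl carbon. Among the compounds with values here, no measured step bears on this part of the core; the only step known concerns a methoxy on an aromatic carbon and says nothing about the group on the carbonyl carbon. The group that leaves carries a bromine and the group that enters carries a methyl, and the measured pair gives no size or direction for either change. The expectation is therefore no step beyond the scatter, a 1.0-fold lower number from compound 1 to compound 3 (0.01 log units; within the scatter), with a wide range around it. Compound 3 is estimated at 30000 nM in this assay, expected to fall between 8000 nM and 110000 nM.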

Compound 3, concentration for 50% growth inhibition: < 100 nM
Compound 3 gave a limit, no number; the forecaster's own chance of this, stated with the estimate: 10%; middle value at least 300-fold (2.47 log units) away from the limit.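

The group on the carbonyl carbon proves to be a place where the read-out moves strongly: in this assay, exchanging 5-bromo-1H-indol-3-yl for 2-methyl-1H-indol-3-yl gives an at least 300-fold lower number from compound 1 to compound 3 (2.48 log units; beyond the scatter), whereas the methoxy change on the shared core gave only a 1.0-fold higher number from compound 1 to compound 2 (0.02 log units; within the scatter). Compound 3 reads < 100 nM, which is a limit of the assay and not a number. The full size of the step therefore stays open, and a single exchange removes the bromine and adds the methyl together, so this result cannot divide the effect between them, with only one value in the set at this limit: the limit of < 100 nM in this assay, at which 1 of the 3 values shown sits.

An unsubstituted 1H-indol-3-yl group, carrying neither bromine nor methyl, would separate the two changes, and an ethyl group or a carboxylic acid in place of the methyl would test how much this position tolerates. Going by these compounds alone, it also remains open whether removing the methoxy still leaves the read-out unmoved when the group on the carbonyl carbon is 2-methyl-1H-indol-3-yl, since the only measured methoxy step carries 5-bromo-1H-indol-3-yl.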